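The source may hold more compounds than are shown below. What is called first, only, known or untested is meant among the compounds shown, and "the series" means these compounds.

Measured compounds:
- compound 1 `CC(C)c1c(C(=O)N2CCC[C@H](c3ccccc3)C2)nn(-c2ccc(F)cc2)c1OC[C@@H](O)C[C@@H](O)CC(=O)O` gives 4.8 nM in an assay on microsomes from liver for inhibition of 3-hydroxy-3-methylglutaryl-coenzyme A reductase (Rattus norvegicus); on this read-out higher numbers stand for weaker inhibition and lower numbers for stronger inhibition
- compound 2 `CC(C)c1c(C(=O)N(C)Cc2cccc(F)c2)nn(-c2ccc(F)cc2)c1OC[C@@H](O)C[C@@H](O)CC(=O)O` gives 14 nM in this assay
- compound 3 `COc1cccc(CN(C)C(=O)c2nn(-c3ccc(F)cc3)c(OC[C@@H](O)C[C@@H](O)CC(=O)O)c2C(C)C)c1` gives 21 nM in this assay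

Compound 3 has the highest number of the three in this assay. Its nearest neighbour is compound 2: the step of a 1.5-fold higher number from compound 2 to compound 3 (0.18 log units; within the scatter) is within the scatter, so the two cannot be ordered. The gap to compound 1 is larger, as the step of a 4.4-fold higher number from compound 1 to compound 3 (0.64 log units; beyond the scatter) shows; the parallel step a 2.9-fold higher number from compound 1 to compound 2 (0.46 log units; beyond the scatter) points the same way.

Compound 4 `CC(C)c1c(C(=O)N(C)Cc2ccc(F)cc2)nn(-c2ccc(F)cc2)c1OC[C@@H](O)C[C@@H](O)CC(=O)O` is the next member. It differs from compound 3 in one place: 4-fluorophenyl in place of 3-methoxyphenyl on a saturated chain carbon bound to an amide-type nitrogen.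

For the measured compounds named here, no measured step swaps these two groups directly. Going by the values given here, the only step touching the same ring is the change from compound 2 to compound 3, a 1.5-fold higher number from compound 2 to compound 3 (0.18 log units; within the scatter), which stayed within the scatter; compound 1, which carries a different amide group altogether, gives no further guidance. On that basis the step of a 1.5-fold lower number from compound 3 to compound 4 (0.18 log units; within the scatter) is expected to be small, at most a slight move toward a lower number, and is not expected to pass beyond the scatter. Compound 4 is therefore estimated at 14 nM in this assay, with a range from 6 nM to 35 nM.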

Compound 4, half-maximal inhibitory concentration: 18 nM
Compound 4: middle estimate off by 1.3-fold (0.11 log units), on the low side, within the range that was stated.
By their numbers in this assay, from the lowest: compound 1; then compounds 2, 4 and 3 (each within the scatter of the next).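

Working notes on the benzyl amides in this assay: both a 1.2-fold lower number from compound 3 to compound 4 (0.07 log units; within the scatter) and a 1.3-fold higher number from compound 2 to compound 4 (0.11 log units; within the scatter) stay within the scatter, so 4-fluorophenyl on a saturated chain carbon bound to an amide-type nitrogen cannot be told apart from 3-methoxyphenyl or 3-fluorophenyl there. The earlier compounds shown here showed only that methoxy and fluoro could be exchanged on the ring with the substituent kept in one place, whereas this result extends the same flat reading to a ring with the substituent printed as 4-fluoro. The gap to the 3-phenylpiperidin-1-yl amide remains, with a 3.8-fold higher number from compound 1 to compound 4 (0.57 log units; beyond the scatter) lying beyond the scatter, and no measurement available here speaks to what lies behind either the flat ring changes or this gap.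

Still open, as far as these compounds go, is whether the flat reading holds for very different groups on this ring, such as a carboxylic acid, a dimethylamino group or a trifluoromethyl group, or for an unsubstituted phenyl. Also open, from the compounds shown here alone, is how a longer chain between the amide nitrogen and the ring, or a 3-(4-fluorophenyl)piperidin-1-yl amide, would read in this assay.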